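Fluoro for methyl on the sulfanyl-linked ring

The source may hold more compounds than are shown below. What is called first, only, known or untested is meant among the compounds shown, and "the series" means these compounds.

Of the compounds shown here, two sharing one core have been measured in an assay for inhibition of sodium- and chloride-dependent glycine transporter 1 (Homo sapiens); a higher number here means a weaker inhibitor, a lower number a stronger inhibitor. Compound 1 `COc1ccc(Sc2ccccc2N2C[C@@H](C)N(CC(=O)O)C[C@@H]2C)cc1` gives 160 nM. Within the data shown here, compound 2 `Cc1ccc(Sc2ccccc2N2CC(C)N(CC(=O)O)CC2C)cc1` gives 550 nM, the highest of the two numbers; its nearest neighbour is compound 1, whose number is lower by a margin that lies beyond the usual scatter, although the two structures differ in more than one place and no single step between them is recorded.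

Compound 3 `CC1CN(c2ccccc2Sc2ccc(F)cc2)C(C)CN1CC(=O)O` has not yet been measured in this assay. It differs from compound 2 by fluoro in place of methyl on an aromatic carbon, with the group count unchanged and no donor or acceptor gained or lost.

Among the measured compounds shown here, no measured pair isolates this exchange, so the size of the step rests on expectation alone. The step from compound 2 to compound 3 is expected to be small, a 1.4-fold lower number from compound 2 to compound 3 (0.14 log units; within the scatter), a modest move toward a lower number that may not exceed the scatter. Compound 3 is therefore estimated at 400 nM, within a range from 150 nM to 1100 nM.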

Compound 3, half-maximal inhibitory concentration: 1900 nM
Compound 3: the middle estimate sits 4.8-fold (0.68 log units) below what was measured; the whole stated range lies below it.
By their numbers in this assay, from the lowest: compound 1; then compound 2; then compound 3.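

Fluoro in place of methyl, on an aromatic carbon para to a large group, is the first single change that can be read in this series, and in this assay it gives a 3.5-fold higher number from compound 2 to compound 3 (0.54 log units; beyond the scatter). This position is therefore not indifferent to its substituent: an exchange of one heavy atom for another, with no hydrogen-bond donor or acceptor gained or lost, is enough to move the number beyond the scatter, and on this core the 4-fluorophenyl compound is the weaker inhibitor of the pair, not the near equal of the 4-methylphenyl compound. Nothing available here bears on the reason for this rise.

Going by these compounds, with only methyl and fluoro comparable at this place, it remains open where chloro, trifluoromethyl, nitrile or a plain unsubstituted phenyl ring would fall, and so whether the rise belongs to fluoro alone or is part of a wider trend. On these data alone, it is also open whether the same exchange would produce a step of this size on the core of compound 1, with its defined stereochemistry.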